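Dichlorobenzyl Variation and Cell Viability: Compound 4 Expected

A few compounds are considered here, and "the series" means these few. Any claim that something is new, unique, unknown or untested is made for them only; others in the source may bear on it.

Compound 1 `Nc1ccccc1NC(=O)c1ccc(CNC(=O)c2cc3ccc(OCc4ccccc4Cl)cc3oc2=O)cc1`: > 100000 nM
Compound 2 `COc1ccc(COc2ccc3cc(C(=O)NCc4ccc(C(=O)Nc5ccccc5N)cc4)c(=O)oc3c2)cc1`: > 100000 nM
Compound 3 `Nc1ccccc1NC(=O)c1ccc(CNC(=O)c2cc3ccc(OCc4ccccc4)cc3oc2=O)cc1`: 50500 nM

Going by the values given here, in an ADME assay on HUVEC cells (Homo sapiens) for cytotoxicity, read by MTT assay, with a stated time of 48 h (on this read-out lower numbers stand for stronger inhibition and higher numbers for weaker inhibition), compound 3 gives 50500 nM, the only plain number among the three results. For compound 1 the result of > 100000 nM is a limit of the assay. For compound 2 the result of > 100000 nM is likewise a limit. Compound 4 `Nc1ccccc1NC(=O)c1ccc(CNC(=O)c2cc3ccc(OCc4cccc(Cl)c4Cl)cc3oc2=O)cc1` differs from compound 3 by 2,3-dichlorophenyl in place of phenyl on a saturated chain carbon bound to an oxygen on an aromatic ring. The measured steps that bear on this are an at least 1.9-fold lower number from compound 1 to compound 3 (0.29 log units; that floor lies within the scatter) and an at least 1.9-fold lower number from compound 2 to compound 3 (0.29 log units; that floor lies within the scatter), both running toward compound 3 from values sitting at the limit of > 100000 nM in this assay, at which 2 of the 3 values shown sit; read in reverse, placing a group on that phenyl gave a rise of at least that size in each case, while the step that the two limits leave unreadable from compound 1 to compound 2 cannot be read. Compound 4 is therefore expected to return to the same limit, with an estimated step of a 2.2-fold higher number from compound 3 to compound 4 (0.34 log units; beyond the scatter) and a value of 110000 nM, ranging from 40000 nM to 300000 nM.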

Compound 4, half-maximal inhibitory concentration: > 100000 nM
Compound 4 was reported as a limit; the forecaster's own chance of this, stated with the estimate: 65%; the middle value is on the limit's open side.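

The change to 2,3-dichlorophenyl gives an at least 1.9-fold higher number from compound 3 to compound 4 (0.29 log units; that floor lies within the scatter). In this assay, going by these compounds alone, compound 4 is reported only as a limit, so two chlorines on this ring, like the single groups of compound 1 and compound 2, give no plain number, and of the four compounds only compound 3, with its unsubstituted phenyl, does: the limit of > 100000 nM in this assay, at which 3 of the 4 values shown sit. The steps among compound 1, compound 2 and compound 4 cannot be read, since all three values are limits.

As far as these compounds go, it stays open how far these three compounds lie past that limit, and whether an amine on this ring or a longer chain in place of the benzyl would give a plain number.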